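Dropping the hydroxyl and fluorine: a step into the unknown

The compounds below may be only part of what the source reports. "The series", "measured", "known", "first", "only" and "open" are said of these compounds alone.

Among the compounds with values here, compound 2 `Cc1cnc(Nc2ccnn2C)nc1-c1cc2n(c1)C(=O)N([C@H](CO)c1ccc(F)c(Cl)c1)C2` is one of two compounds measured in a functional assay on COLO 205 cells (Homo sapiens) for antiproliferative activity, read by luminescence, with a stated time of 72 h (a lower number here means a stronger inhibitor, a higher number a weaker inhibitor), where compound 2 gives 94.9 nM. Within the data shown here, its only neighbour is compound 1 `Cc1cnc(Nc2ccnn2C)nc1-c1cc2n(c1)C(=O)N([C@H](CO)c1ccc(Cl)c(F)c1)C2`, which in this assay gives 92.2 nM; the step of a 1.0-fold higher number from compound 1 to compound 2 (0.01 log units; within the scatter) shows that swapping the halogen pattern on the aryl ring made no difference beyond the scatter. Compound 3 `Cc1cnc(Nc2ccnn2C)nc1-c1cc2n(c1)C(=O)N([C@H](C)c1cccc(Cl)c1)C2` has not yet been measured. It differs from compound 2 by 1-(3-chlorophenyl)ethyl in place of 1-(3-chloro-4-fluorophenyl)-2-hydroxyethyl on an amide-type nitrogen in a ring. Among the measured compounds shown here, the one measured step bears on this change only in part: it tells that the aryl halogens are tolerant to rearrangement, but no compound here tests the loss of the hydroxyl and of the ring fluorine together, nor the methyl that enters in their place. The expectation for compound 3 therefore rests on thin ground, and a modestly weaker result, a step of a 1.9-fold higher number from compound 2 to compound 3 (0.28 log units; within the scatter) in this assay, is expected with a wide range. In this assay compound 3 is estimated at 180 nM, between 60 nM and 600 nM.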

Compound 3, half-maximal inhibitory concentration: "not active" (no number reported)
Compound 3: no number reported, and the estimate cannot be compared.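

In this assay, within the data shown here, compound 3 is reported as "not active" with no number, so no step from compound 2 to compound 3 can be read. No evidence shown here accounts for this result. The compounds shown leave open which part of the change from 1-(3-chloro-4-fluorophenyl)-2-hydroxyethyl to 1-(3-chlorophenyl)ethyl goes with it.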